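A few compounds are considered here, and "the series" means these few. Any claim that something is new, unique, unknown or untested is made for them only; others in the source may bear on it.

In a functional assay on HeLa cells (Homo sapiens) for cytotoxicity, read by MTT assay (on this read-out lower numbers stand for stronger inhibition and higher numbers for weaker inhibition), compound 1 `COc1ccc(C#Cc2cc(OC)c(OC)c(OC)c2)cc1O` gives 1540 nM as a measured number. Compound 2 `COc1ccc(C#Cc2cc(OC)c(OC)c(OC)c2)cc1N` gives > 30000 nM there, which is a limit of the assay and not a number, so it has no exact place on the scale.

Compound 3 `COc1ccc(C#Cc2cc(OC)c(OC)c(OC)c2)cc1NC(=O)OC(C)(C)C` is reached from compound 2 by the change tert-butoxycarbonyl in place of hydrogen on a nitrogen on an aromatic ring with tert-butoxycarbonyl in place of hydrogen on a nitrogen on an aromatic ring. Among the measured compounds shown here, only one measured step bears on this, and only indirectly: an at least 19-fold higher number from compound 1 to compound 2 (1.28 log units; beyond the scatter) with amino in place of hydroxy on an aromatic carbon, a large step beyond the scatter. For the measured compounds named here, no measured step covers a substitution on the nitrogen itself, so the size of this change has no direct precedent.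

Compound 3 lacks the hydroxy, so the large loss seen in an at least 19-fold higher number from compound 1 to compound 2 (1.28 log units; beyond the scatter) is not expected to be recovered. The step expected is small, estimated as an at least 1.2-fold lower number from compound 2 to compound 3 (0.07 log units; that floor lies within the scatter) and possibly not resolved by the assay, since a further limit is a likely outcome. In this assay the estimated value for compound 3 is 25000 nM with a range from 6000 nM to 30000 nM as expected.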

Compound 3, half-maximal inhibitory concentration: > 30000 nM
Compound 3 ended at the assay's limit (the forecaster's own chance of this, stated with the estimate: 60%); at least 1.2-fold (0.07 log units) between middle value and limit.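

In this assay, tert-butoxycarbonyl on the nitrogen does not bring the series back into the measurable range: compound 3 gives > 30000 nM, which is a limit of the assay and not a number. With (tert-butoxycarbonyl)amino in place of hydroxy on an aromatic carbon the series shows an at least 19-fold higher number from compound 1 to compound 3 (1.28 log units; beyond the scatter), a large step like an at least 19-fold higher number from compound 1 to compound 2 (1.28 log units; beyond the scatter), so at this position the loss is not confined to the free amino group and holds for both nitrogen groups shown. The step on the nitrogen itself cannot be read, since neither end of it is a number: the limit of > 30000 nM in this assay, at which 2 of the 3 values shown sit.

As far as these compounds go, how far compound 2 and compound 3 lie past the limit stays open, and with it whether tert-butoxycarbonyl changes anything relative to the free amino group. Among the compounds shown here, also open is whether a smaller acyl group on the nitrogen, such as acetyl, or a hydroxymethyl group in place of the hydroxy would return a measured value near the one compound 1 gives, 1540 nM.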